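Phenyl in Place of Pyridin-4-yl: Estimating Compound 4

The source may report more compounds than this note shows. Statements on the series, on what has been measured and on what is new or still open speak of the compounds shown alone.

Compound 1, `Nc1ccccc1NC(=O)c1ccc(CSC(=S)N2CCN(c3ccncc3)CC2)cc1`: 1270 nM
Compound 2, `Nc1ccccc1NC(=O)c1ccc(CSC(=S)N2CCc3cc(Cl)ccc32)cc1`: 5280 nM
Compound 3, `Nc1ccccc1NC(=O)c1ccc(CSC(=S)N2CCc3ccccc32)cc1`: 4050 nM

These three compounds share one core and were tested in a functional assay on A-375 cells (Homo sapiens) for antiproliferative activity, read by CCK-8 assay, with a stated time of 72 h; on this read-out lower numbers stand for stronger inhibition and higher numbers for weaker inhibition. Compound 1 gives the lowest number of the three, and its gaps to compound 3 and to compound 2 both lie beyond the scatter. Going by the values given here, the only measured single-point step, a 1.3-fold lower number from compound 2 to compound 3 (0.12 log units; within the scatter), concerns a different group on a different ring and so does not bear on the change followed here. Compound 4, `Nc1ccccc1NC(=O)c1ccc(CSC(=S)N2CCN(c3ccccc3)CC2)cc1`, differs from compound 1 by phenyl in place of pyridin-4-yl on an amine nitrogen in a ring. Among the compounds with values here, with no measured step of this kind to lean on, the expected move is none beyond the scatter in this assay. Compound 4 is therefore estimated at 1600 nM, with a range from 600 nM to 4500 nM. This estimate means an expected step of a 1.3-fold higher number from compound 1 to compound 4 (0.10 log units; within the scatter).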

Compound 4, half-maximal inhibitory concentration: 3670 nM
Beside the measured number, compound 4's estimate is 2.3-fold (0.36 log units) below it; the measured number falls inside the stated range.
By their numbers in this assay, from the lowest: compound 1; then compounds 4, 3 and 2 (each within the scatter of the next).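

Phenyl in place of pyridin-4-yl on an amine nitrogen in a ring gives a 2.9-fold higher number from compound 1 to compound 4 (0.46 log units; beyond the scatter) in this assay. This single step shows that the number at this position responds when one ring nitrogen is exchanged for carbon, a change that also removes the hydrogen-bond acceptor counted on pyridin-4-yl. Nothing measured here explains the shift.

From the compounds shown here alone, it remains open how pyridin-3-yl, pyridin-2-yl or a simple methyl would behave at this place. Going by these compounds, it is also open whether the same exchange would give a similar step on a different core.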